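Cytotoxicity notes on three measured analogues and one pending

This account rests on a few compounds, and the source may have more. Where it says the series, first, only, none or still open, it means among the compounds named here.

Measured so far in an ADME assay on MT2 cells (Homo sapiens) for cytotoxicity, read by MTT assay; on this read-out higher numbers stand for lower toxicity in this test and lower numbers for higher toxicity in this test:
- compound 1 `Fc1cccc(F)c1Cc1cnc(Nc2ccc(Oc3ccncc3)c(Cl)c2)o1` gives 21000 nM
- compound 2 `Fc1cccc(F)c1Cc1cnc(Nc2ccc(Oc3cccnc3)cc2)o1` gives 22000 nM
- compound 3 `Fc1cccc(F)c1Cc1cnc(Nc2ccc(Oc3ccncc3)cc2)o1` gives 21000 nM

Compound 3 stands level with compound 1 at the digits shown, the two together making the lowest of the three numbers. Its nearest neighbour is compound 1, with no change at the digits printed from compound 1 to compound 3 (within the scatter). Compound 2 is the furthest, yet the step from it is also small: a 1.0-fold lower number from compound 2 to compound 3 (0.02 log units; within the scatter). All three numbers sit inside one band of scatter, so nothing in this assay separates them.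

Compound 4 `O=c1ccn(CCOc2ccc(Nc3ncc(Cc4c(F)cccc4F)o3)cc2)c(=O)[nH]1` is the next member. Compared with compound 3 it carries a different group on the oxygen on the aromatic ring: a group of 10 heavy atoms (6 carbon, 2 nitrogen, 2 oxygen; one six-membered aromatic ring with 2 hetero atoms) in place of a group of 6 heavy atoms (5 carbon, 1 nitrogen; one six-membered aromatic ring with 1 hetero atom), on an oxygen on an aromatic ring.

Among the compounds with values here, two measured steps bear on this position, though only loosely. Exchange of one pyridinyl for another on that oxygen gave a 1.0-fold lower number from compound 2 to compound 3 (0.02 log units; within the scatter), and loss of chloro on the neighbouring aromatic carbon gave no change at the digits printed from compound 1 to compound 3 (within the scatter); neither moved the number beyond scatter. Within the data shown here, no measured step covers a group of the kind that enters here, so the expectation rests on the flatness of the series alone. The step from compound 3 to compound 4 is expected to be a 1.0-fold higher number from compound 3 to compound 4 (0.02 log units; within the scatter), that is, no change beyond the scatter. Compound 4 is therefore estimated at 22000 nM, with a range from 8000 nM to 60000 nM.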

Compound 4, half-maximal cytotoxic concentration: 73000 nM
For compound 4 the middle estimate is 3.3-fold (0.52 log units) below the measured one; measured number above the stated range.
By their numbers in this assay, from the lowest: compounds 1, 3 and 2 (each within the scatter of the next); then compound 4.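

In this assay the position on the oxygen on an aromatic ring turns out able to move the number beyond the scatter: the group of 10 heavy atoms gives a 3.5-fold higher number from compound 3 to compound 4 (0.54 log units; beyond the scatter) in place of pyridin-4-yl and a 3.3-fold higher number from compound 2 to compound 4 (0.52 log units; beyond the scatter) in place of the other pyridinyl, both towards lower toxicity in this test. The exchange between the two pyridinyl groups had stayed within the scatter, so the earlier flatness holds for those two groups only and does not extend to the position as a whole. No measured evidence bears on what lies behind this shift.

Still open, from the compounds shown here alone, is which feature of the entering group goes with the higher number, as its ring, its two double bonds outside aromatic rings and its hydrogen-bond donor all enter in a single change. Equally open, going by these compounds, is whether an amine, a carboxylic acid or a plain longer chain on the same oxygen would also move the number beyond the scatter, and whether chloro on the shared core would stay as silent with the new group as it did with pyridin-4-yl.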